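Seven-membered core: substitution at the ring carbon

A few compounds are considered here, and "the series" means these few. Any claim that something is new, unique, unknown or untested is made for them only; others in the source may bear on it.

Working notes on a series sharing the core of compound 1 `CCOC(=O)C(=O)Nc1cccccc1=O`. In a functional assay on the whole organism (strain Sprague-Dawley CD) for inhibition, with Rattus norvegicus as the target, read by paw edema, at a dose of 30 mg/kg by the oral route (on this read-out higher numbers stand for a stronger effect at the one dose given and lower numbers for a weaker effect), compound 1 gives 79%, the highest of the three numbers recorded. Compound 2 `CCOC(=O)C(=O)Nc1ccccc(C)c1=O`, which carries methyl in place of hydrogen on an aromatic carbon, gives 6% in this assay; compound 3 `CCOC(=O)C(=O)Nc1ccccc(N(C)S(=O)(=O)c2ccc(C)cc2)c1=O` gives 3%. Both differ from compound 1 by a group on the seven-membered ring, and both numbers are far below it.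

Compound 4 `CCOC(=O)C(=O)Nc1ccccc(NC)c1=O` is not yet measured. It differs from compound 1 as follows: methylamino in place of hydrogen on an aromatic carbon. Among the measured compounds shown here, the only step recorded that bears directly on this change is a number 73 percentage points lower from compound 1 to compound 2 (beyond the scatter), a large loss on adding a group at an aromatic carbon of the ring; the value of compound 3 points the same way without being a single-change step. A step in this assay of similar direction is therefore expected for compound 4, namely a number 67 percentage points lower from compound 1 to compound 4 (beyond the scatter). Compound 4 is estimated at 12%, within 0% to 40%.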

Compound 4, a percentage reported as inhibition, in the whole organism at one dose (the size of the read-out at that dose, not a potency): 0%
Beside the measured number, compound 4's estimate is 12 percentage points above it; measured number inside the range.
By their numbers in this assay, from the lowest: compounds 4, 3 and 2 (each within the scatter of the next); then compound 1.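

In this assay, methylamino in place of hydrogen gives a number 79 percentage points lower from compound 1 to compound 4 (beyond the scatter), so the loss seen with methyl on this aromatic carbon, two ring bonds from the ring atom that bears a group of 8 heavy atoms, also appears with a second single group, one that brings a nitrogen, a hydrogen-bond donor and a hydrogen-bond acceptor. Exchanging methyl for methylamino gives a number 6 percentage points lower from compound 2 to compound 4 (within the scatter), so these two groups cannot be told apart on this read-out, and of the three single groups compared here at this carbon, only hydrogen keeps the effect. No measurement on hand bears on why the effect is lost.

Going by these compounds, whether any group at this carbon can keep the effect remains open; a fluorine atom, a hydroxyl or a carboxylic acid would test this. Also open, on these data alone, is whether the same changes at other ring carbons of the shared core would lose the effect.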